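A few compounds are considered here, and "the series" means these few. Any claim that something is new, unique, unknown or untested is made for them only; others in the source may bear on it.

Measured compounds: compound 1 `C/C(=C\c1cc(-c2ccc(C)cc2)co1)C(N)=O`, compound 2 `C/C(=C\c1cc(-c2ccc(F)cc2)co1)C(N)=O`, compound 3 `C/C(=C\c1cc(-c2ccc(C)nc2)co1)C(N)=O`.

In a functional assay on T-24 cells (Homo sapiens) for cytotoxicity, read by CCK-8 assay, with a stated time of 24 h (on this read-out higher numbers stand for weaker inhibition and lower numbers for stronger inhibition), compound 1 gives > 50000 nM, which is a limit of the assay and not a number. In this assay compound 2 gives > 50000 nM, again a limit. Compound 3 gives > 50000 nM in this assay, also a limit. The change from compound 1 to compound 2 is fluoro in place of methyl on an aromatic carbon; the step it made, a step that the two limits leave unreadable from compound 1 to compound 2, cannot be read because of the limit of > 50000 nM in this assay, at which 3 of the 3 values shown sit.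

Compound 4 `C/C(=C\c1cc(-c2ccc(F)nc2)co1)C(N)=O` is not yet measured. From compound 3 to compound 4 the change is fluoro in place of methyl on an aromatic carbon; it is the same kind of change as from compound 1 to compound 2, but the place differs: in compound 1 the ring is of carbon only, whereas in compound 3 the ring holds one nitrogen and the change sits next to the ring nitrogen. The difference between the two cores of compound 1 and compound 3 is not broken down here.

Among the measured compounds shown here, because of the limit of > 50000 nM in this assay, at which 3 of the 3 values shown sit, no measured step in this assay sets a size; the step from compound 3 to compound 4 is therefore expected to be about a step that the limit leaves unreadable from compound 3 to compound 4, unreadable like the earlier one. Compound 4 is expected to give about 80000 nM in this assay, most likely again as a limit.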

Compound 4, half-maximal inhibitory concentration: > 50000 nM
Compound 4 was reported as a limit; the forecaster's own chance of this, stated with the estimate: 85%; the middle value does not contradict the limit.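

No step can be read from compound 3 to compound 4, as with the earlier methyl to fluoro change, since neither compound gives a number in this assay: the limit of > 50000 nM in this assay, at which 4 of the 4 values shown sit.

The compounds shown leave open how large the methyl to fluoro step is on either core, and whether any change to the shared core gives a measurable value in this assay.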